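Replacing the tert-butyl group on the benzamide of compound 1

The source may hold more compounds than are shown below. What is called first, only, known or untested is meant among the compounds shown, and "the series" means these compounds.

Measured so far:
compound 1 `CCOC(=O)c1sc(-c2cccc(NC(=O)c3ccc(C(C)(C)C)cc3)c2)nc1Nc1ccc(N2CCN(C)CC2)cc1`: 4.22%
compound 2 `CCOC(=O)c1sc(-c2cccc(NC(=O)c3ccccc3)c2)nc1Nc1ccc(N2CCN(C)CC2)cc1`: 42%
compound 3 `CCOC(=O)c1sc(-c2cccc(NC(=O)c3ccc(C#N)cc3)c2)nc1Nc1ccc(N2CCN(C)CC2)cc1`: 79.1%

In a functional assay on Raji cells (Homo sapiens) for antiproliferative activity, read by CCK-8 assay, with a stated time of 72 h, tested at 40 uM (a lower number here means less inhibition, a higher number more inhibition at the concentration tested (going by the name of the read-out)), compound 1 gives 4.22%, the lowest of the three numbers; compound 2 gives 42% and compound 3 gives 79.1%, both beyond the scatter above it. Compound 4 `CCOC(=O)c1sc(-c2cccc(NC(=O)c3ccc(F)c(Cl)c3)c2)nc1Nc1ccc(N2CCN(C)CC2)cc1` differs from compound 1 by 3-chloro-4-fluorophenyl in place of 4-(tert-butyl)phenyl on a carbonyl carbon. Within the data shown here, two measured steps bear on this change, since each also removes the tert-butyl group: a number 37.8 percentage points higher from compound 1 to compound 2 (beyond the scatter) and a number 74.9 percentage points higher from compound 1 to compound 3 (beyond the scatter). Both were large and upward, so a large upward step from compound 1 to compound 4 is expected in this assay, a number 45.8 percentage points higher from compound 1 to compound 4 (beyond the scatter). Compound 4 is therefore estimated at 50%, with a range from 20% to 80%.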

Compound 4, a percentage reported as inhibition, at one concentration (the size of the read-out at that concentration, not a potency): 20.7%
The estimate for compound 4 lay 29.3 percentage points above the measured number, within the range that was stated.
By their numbers in this assay, from the lowest: compound 1; then compound 4; then compound 2; then compound 3.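

Losing the tert-butyl group does not by itself give a high number: 3-chloro-4-fluorophenyl yields a number 16.5 percentage points higher from compound 1 to compound 4 (beyond the scatter) but falls short of plain phenyl, with a number 21.3 percentage points lower from compound 2 to compound 4 (beyond the scatter) and further short of 4-cyanophenyl, with a number 58.4 percentage points lower from compound 3 to compound 4 (beyond the scatter) in that comparison. The group on this carbonyl carbon therefore matters beyond the absence of tert-butyl: adding the two halogens to phenyl lowers the number, while adding cyano raises it. Nothing measured here explains this order. Whether chlorine or fluorine alone accounts for the drop stays open. So does the outcome with an amine or a carboxylic acid on this ring.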